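The compounds below may be only part of what the source reports. "The series", "measured", "known", "first", "only" and "open" are said of these compounds alone.

Working notes on the series. Of the compounds shown here, three have been measured in a physicochemical assay for lipophilicity; on this read-out lower numbers stand for lower lipophilicity and higher numbers for higher lipophilicity. Compound 1 `CCN(Cc1cccnc1)c1ccc(C(=O)N2CCc3ccc(OS(N)(=O)=O)cc3C2)cc1` gives 1.93. Compound 3 `NS(=O)(=O)Oc1ccc2c(c1)CN(C(=O)c1ccc(N3CCC(N4CCCCC4)CC3)cc1)CC2` gives 1.93, level with compound 1 at the digits shown, and together these two stand as the lowest of the three numbers. Compound 2 `CCN(Cc1ccccc1)c1ccc(C(=O)N2CCc3ccc(OS(N)(=O)=O)cc3C2)cc1` gives 3.08, the number furthest from compound 1. Within the data shown here, the only measured pair that differs in one place is a number 1.15 log units higher from compound 1 to compound 2 (beyond the scatter), a large step beyond the scatter.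

Compound 4 `CCCN(Cc1ccccc1)c1ccc(C(=O)N2CCc3ccc(OS(N)(=O)=O)cc3C2)cc1` is not yet measured. Its change from compound 1 is benzyl(propyl)amino in place of ethyl((pyridin-3-yl)methyl)amino on an aromatic carbon. The step from compound 1 to compound 2 bears on it directly, since that step also puts phenyl in place of pyridin-3-yl on the chain carbon bound to the nitrogen on the aromatic ring. Among the measured compounds shown here, compound 4 differs from compound 2 only in propyl in place of ethyl on that nitrogen, and no measured pair covers this part; the range is widened for it. For the measured compounds named here, the expected step in this assay is therefore upward, at least as large as the one from compound 1 to compound 2. Compound 4 is expected to give 3.5, within 3 to 4, which is an expected step of a number 1.57 log units higher from compound 1 to compound 4 (beyond the scatter).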

Compound 4, partition coefficient: 1.93
The estimate for compound 4 lay 1.57 log units above the measured number, and the stated range ends above it.
By their numbers in this assay, from the lowest: compounds 1, 3 and 4 (each within the scatter of the next); then compound 2.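

In this assay, benzyl(propyl)amino in place of ethyl((pyridin-3-yl)methyl)amino on the aromatic carbon gives no change at the digits printed from compound 1 to compound 4 (within the scatter), so the rise seen with phenyl in place of pyridin-3-yl does not survive once the chain on the nitrogen is propyl. Propyl in place of ethyl, a change no earlier pair covered, gives a number 1.15 log units lower from compound 2 to compound 4 (beyond the scatter), which shows that this single added methyl can shift the read-out by a large step at this position. Nothing available bears on why the read-out moves this way.

Going by these compounds, it remains open whether a butyl chain on the same nitrogen would stay level with propyl or move away from it. Also open, on these data alone, is what pyridin-3-yl in place of phenyl would give with the propyl chain kept.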